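Amide nitrogen substitution on the sulfonamide triazole core

This account rests on a few compounds, and the source may have more. Where it says the series, first, only, none or still open, it means among the compounds named here.

Going by the values given here, compound 2 `NC(=O)c1nc(-c2ccccc2)n(-c2ccc(S(N)(=O)=O)cc2)n1` is the primary amide of the shared core; in a functional assay on the whole organism for inhibition, with Rattus norvegicus as the target, read by paw edema, with stated times of 30 min and 4 h, at a dose of 0.28 mmol/kg by the oral route (a lower number here means less inhibition, a higher number more inhibition at the dose given (going by the name of the read-out)), compound 2 gives 49%, the lower of the two numbers measured so far. Compound 1 `CC(=O)c1ccc(NC(=O)c2nc(-c3ccccc3)n(-c3ccc(S(N)(=O)=O)cc3)n2)cc1` carries a 4-acetylphenyl group on the amide-type nitrogen, and in this assay compound 1 gives 64%. Among the compounds with values here, the one measured step runs a number 15 percentage points lower from compound 1 to compound 2 (beyond the scatter): loss of the aryl group from the amide-type nitrogen goes with a drop beyond the scatter.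

Compound 3 `NS(=O)(=O)c1ccc(-n2nc(C(=O)NC3CCCCC3)nc2-c2ccccc2)cc1` differs from compound 2 by cyclohexyl in place of hydrogen on an amide-type nitrogen. Within the data shown here, the only step that bears on this change is a number 15 percentage points lower from compound 1 to compound 2 (beyond the scatter), read in reverse: a substituent returns to the amide-type nitrogen, though here a six-membered non-aromatic ring of carbon only rather than the 4-acetylphenyl of compound 1. Whether such a ring brings the same gain cannot be read from the two measured compounds. The expected step is a number 8 percentage points higher from compound 2 to compound 3 (within the scatter), a modest rise. For compound 3 in this assay the estimated value is 57%, with a range from 42% to 70%.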

Compound 3, a percentage reported as inhibition, in the whole organism at one dose (the size of the read-out at that dose, not a potency): 53%
For compound 3 the middle estimate is 4 percentage points above the measured one, within the range that was stated.
By their numbers in this assay, from the lowest: compounds 2 and 3 (each within the scatter of the next); then compound 1.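

In this assay the entry of cyclohexyl on the amide-type nitrogen gives a number 4 percentage points higher from compound 2 to compound 3 (within the scatter) and so, in this pair, a substituent on that nitrogen does not by itself reproduce the higher number of compound 1. The identity of the substituent does matter at this position: cyclohexyl against 4-acetylphenyl gives a number 11 percentage points lower from compound 1 to compound 3 (beyond the scatter) and only the 4-acetylphenyl group stands clear of the primary amide among the three compounds, which is a reading of these three alone and not a rule for the series. Nothing available on these compounds offers an explanation for the gap between the two substituents.

From the compounds shown here alone, whether the higher number of compound 1 goes with the aromatic ring or with its acetyl group stays open, and plain phenyl on the same nitrogen would separate the two. Also open, going by these compounds, is how an open chain such as n-butyl, or a basic amine or carboxylic acid carried on the substituent, would read in this assay at this dose.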